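Working notes: from 3-bromophenyl to 4-methoxyphenyl

The source may hold more compounds than are shown below. What is called first, only, known or untested is meant among the compounds shown, and "the series" means these compounds.

Measured so far:
- compound 1 `COc1ccc(OS(=O)(=O)c2ccc(N3CCN(C)C3=O)cc2)cc1`: 95000 nM
- compound 2 `CCCCN1CCN(c2ccc(S(=O)(=O)Oc3cccc(Br)c3)cc2)C1=O`: 85 nM

Both values come from a functional assay on MCF7 cells (Homo sapiens) for antiproliferative activity, read by sulforhodamine B assay, with a stated time of 48 h; on this read-out higher numbers stand for weaker inhibition and lower numbers for stronger inhibition. Of the two, compound 2 at 85 nM holds the lower number and so the stronger inhibition, and the gap to compound 1 at 95000 nM lies well beyond the scatter. For the measured compounds named here, no single-place step between measured compounds exists, so nothing measured sizes the next change directly.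

Not yet measured is compound 3 `CCCCN1CCN(c2ccc(S(=O)(=O)Oc3ccc(OC)cc3)cc2)C1=O`, which carries 4-methoxyphenyl in place of 3-bromophenyl on an oxygen. The rest of compound 2 stays as it is.

In this assay a step beyond the scatter is expected, towards a higher number and weaker inhibition, though one that covers only part of the gap between the two measured compounds. The expected change is an 18-fold higher number from compound 2 to compound 3 (1.25 log units; beyond the scatter). This expectation takes compound 2 at 85 nM as the lower reference and compound 1 at 95000 nM as the upper one, and the range is kept wide. For compound 3 the estimated value is 1500 nM, with an expected range of 150 nM to 15000 nM.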

Compound 3, half-maximal inhibitory concentration: 2500 nM
Compound 3: the middle estimate sits 1.7-fold (0.22 log units) below what was measured; low and high end bracket the measured number.
By their numbers in this assay, from the lowest: compound 2; then compound 3; then compound 1.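

In this assay, compound 3 gives the first direct sizing of the substituent on the oxygen whose other neighbour is the sulfonyl sulfur: 4-methoxyphenyl in place of 3-bromophenyl gives a 29-fold higher number from compound 2 to compound 3 (1.47 log units; beyond the scatter), a large step with the rest of the molecule unchanged. It also isolates the chain on the amide-type nitrogen in the ring, since with 4-methoxyphenyl held fixed, propyl in place of hydrogen on the saturated chain carbon bound to that nitrogen gives a 38-fold lower number from compound 1 to compound 3 (1.58 log units; beyond the scatter), so each of the two places separately moves the number well beyond the scatter. Nothing available accounts for either step.

Because 3-bromophenyl and 4-methoxyphenyl differ in both the substituent and its ring position, the compounds shown do not separate these two changes, and 4-bromophenyl, 3-methoxyphenyl or unsubstituted phenyl would be needed to do so. Also open, as far as these compounds go, is how the number responds along the chain, for example to a longer chain or to an amine at its end.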